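A few compounds are considered here, and "the series" means these few. Any claim that something is new, unique, unknown or untested is made for them only; others in the source may bear on it.

Going by the values given here, in a functional assay on the whole organism with Mus musculus as the target (a higher number here means that more compound is needed for the effect, a lower number that less compound is needed), compound 2 `CCCN1C(=O)CCC1(O)c1cccc(C(F)(F)F)c1` gives 200 mg/kg, the only number so far. Compound 1 `CCN1C(=O)CCC1(O)c1cccc(C(F)(F)F)c1` gives > 100 mg/kg, which is a limit of the assay and not a number.

Compound 3 `CCCCN1C(=O)CCC1(O)c1cccc(C(F)(F)F)c1` differs from compound 2 by one change: methyl in place of hydrogen on a saturated chain carbon, three bonds along the chain from an amide-type nitrogen in a ring. Cut one bond further out, this reads as propyl to butyl on the shared core.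

Among the compounds with values here, the only measured step of this kind is a step that the limit leaves unreadable from compound 1 to compound 2, with methyl in place of hydrogen on a saturated chain carbon, two bonds along the chain from an amide-type nitrogen in a ring. That step offers neither a size nor a direction to carry forward. With compound 2 as the sole numerical anchor in this assay, no shift beyond the scatter is expected, and the range is kept wide. The expected change is no change at the digits printed from compound 2 to compound 3 (within the scatter). For compound 3 the estimated dose is 200 mg/kg, with an expected range from 80 mg/kg to 450 mg/kg.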

Compound 3, dose for half-maximal effect: > 200 mg/kg
Compound 3: no number, only a limit (the forecaster's own chance of this, stated with the estimate: 25%); the middle value sits exactly at the limit.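

In this assay compound 3 gives > 200 mg/kg, which is a limit of the assay and not a number. Even so, methyl in place of hydrogen, three bonds along the chain from an amide-type nitrogen in a ring, gives the first step in the series with a readable direction: a number no lower from compound 2 to compound 3 (the limit leaves the size open); going from propyl to butyl therefore shows no sign of lowering the dose needed, which the step from ethyl to propyl could not show. The two steps involving compound 1 cannot be read, so a trend across ethyl, propyl and butyl cannot be drawn from these compounds.

From the compounds shown here alone, how large the step from propyl to butyl is remains open, as does whether any change at this position can bring the dose under that of compound 2. A longer chain such as pentyl, or a chain carrying an amine or a carboxylic acid, would test whether the direction seen here holds beyond butyl.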